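Replacing the Piperidine Carboxamide with a Methylisoxazole

This account rests on a few compounds, and the source may have more. Where it says the series, first, only, none or still open, it means among the compounds named here.

Measured compounds:
compound 1 `CCN(CC)C(=O)[C@@H]1CCCN(S(=O)(=O)c2ccc(S(=O)(=O)N(CC)CC)cc2)C1`: 6400 nM
compound 2 `CCN(CC)S(=O)(=O)c1ccc(S(=O)(=O)N2CCC[C@@H](C(=O)NC3COC3)C2)cc1`: 2300 nM
compound 3 `CCN(CC)S(=O)(=O)c1ccc(S(=O)(=O)N2CCC[C@@H](C(=O)NC3CN(C(=O)NC(C)(C)C)C3)C2)cc1`: 3400 nM

In a functional assay on MIA PaCa-2 cells (Homo sapiens) for inhibition, read by MTT assay, with a stated time of 7 days (a higher number here means a weaker inhibitor, a lower number a stronger inhibitor), compound 2 gives 2300 nM, the lowest of the three numbers. One step to it lies within the scatter, a 1.5-fold higher number from compound 2 to compound 3 (0.17 log units; within the scatter), and one beyond it, a 2.8-fold lower number from compound 1 to compound 2 (0.44 log units; beyond the scatter); the third step among the measured compounds, a 1.9-fold lower number from compound 1 to compound 3 (0.27 log units; within the scatter), is also within the scatter.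

Compound 4 `CCN(CC)S(=O)(=O)c1ccc(S(=O)(=O)N2CCC[C@@H](c3cc(C)no3)C2)cc1` differs from compound 2 in one place: 3-methyl-1,2-oxazol-5-yl in place of (oxetan-3-yl)carbamoyl on a saturated ring carbon. For the measured compounds named here, all three measured steps keep the carbonyl and vary only what sits on it, and none was large; the change to compound 4 removes the carbonyl and the amide-type nitrogen altogether, so no measured step matches it directly. The measured steps bound the expectation: a step of at most modest size, in either direction, is expected, and a somewhat higher number is judged more likely than a lower one since the carbonyl present in every measured compound is lost. For compound 4 the expected step is a 1.7-fold higher number from compound 2 to compound 4 (0.24 log units; within the scatter). The estimate for compound 4 in this assay is 4000 nM, with a range from 1200 nM to 13000 nM.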

Compound 4, half-maximal inhibitory concentration: 4900 nM
The estimate for compound 4 lay 1.2-fold (0.09 log units) below the measured number; the measured number falls inside the stated range.
By their numbers in this assay, from the lowest: compounds 2, 3, 4 and 1 (each within the scatter of the next, the first and the last beyond it).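

In this assay, for the compounds shown here, the carbonyl and the amide-type nitrogen can both leave this saturated ring carbon without the number moving outside a modest span: a 2.1-fold higher number from compound 2 to compound 4 (0.33 log units; beyond the scatter) is the only step beyond the scatter that the new group produces. Against the diethylcarbamoyl group the picture differs, since a 1.3-fold lower number from compound 1 to compound 4 (0.12 log units; within the scatter) leaves 3-methyl-1,2-oxazol-5-yl and diethylcarbamoyl indistinguishable, so the new ring matches the amide of compound 1 but not the (oxetan-3-yl)carbamoyl group of compound 2. No measurement available here explains either step.

Still open, as far as these compounds go, is whether a longer chain in place of the methyl on the 1,2-oxazole ring changes the number. Also open, from the compounds shown here alone, is how a carboxylic acid or a primary amine on this ring carbon would compare with compound 2.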